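Loss of the aryl sulfonamide: expected return toward inactivity

This account rests on a few compounds, and the source may have more. Where it says the series, first, only, none or still open, it means among the compounds named here.

The series rests on a shared lactone core carrying a triazole on a hydroxylated side chain. Compound 1 `O=C1O[C@H]([C@@H](O)Cn2cc(-c3cccc(O)c3)nn2)C(OCc2ccccc2)=C1OCc1ccccc1` bears a 3-hydroxyphenyl on the triazole. In a functional assay on SW-620 cells (Homo sapiens) for antiproliferative activity, read by MTT assay, with a stated time of 72 h (a lower number here means a stronger inhibitor, a higher number a weaker inhibitor), compound 1 reports only a limit, > 100000 nM, which is the upper limit of the assay (the limit of > 100000 nM in this assay, at which 1 of the 2 values shown sits). Compound 2 `O=C1O[C@H]([C@@H](O)Cn2cc(CNS(=O)(=O)c3ccc(F)cc3)nn2)C(OCc2ccccc2)=C1OCc1ccccc1` carries instead a (((4-fluorophenyl)sulfonyl)amino)methyl group, and in this assay compound 2 gives 41100 nM. For the measured compounds named here, the change amounts to an at least 2.4-fold lower number from compound 1 to compound 2 (0.38 log units; beyond the scatter), so compound 2 stands as the only actual number in the set, the other value being a limit.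

Compound 3 `O=C1O[C@H]([C@@H](O)Cn2cc(CCO)nn2)C(OCc2ccccc2)=C1OCc1ccccc1` differs from compound 2 by hydroxymethyl in place of ((4-fluorophenyl)sulfonyl)amino on a saturated chain carbon bound to an aromatic carbon. Going by the values given here, no measured step covers this change directly; the one step available, an at least 2.4-fold lower number from compound 1 to compound 2 (0.38 log units; beyond the scatter), shows that bringing in the sulfonamide-bearing arm coincided with the only measurable number. Compound 3 lacks that arm and carries a hydroxymethyl in its place. Its number is expected to rise again, quite possibly back to the limit. Compound 3 is estimated at 90000 nM, within 35000 nM to 300000 nM. The expected step is a 2.2-fold higher number from compound 2 to compound 3 (0.34 log units; beyond the scatter).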

Compound 3, half-maximal inhibitory concentration: > 100000 nM
Compound 3: a limit, no number (the forecaster's own chance of this, stated with the estimate: 45%); middle value at least 1.1-fold (0.04 log units) away from the limit.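

For the compounds shown here, replacing ((4-fluorophenyl)sulfonyl)amino with hydroxymethyl on a saturated chain carbon bound to an aromatic carbon gives an at least 2.4-fold higher number from compound 2 to compound 3 (0.38 log units; beyond the scatter), so the one measurable number in this assay does not survive when only the first carbon of that arm remains. Compound 1 could show only that the full arm did better than a 3-hydroxyphenyl; compound 3 adds that a saturated chain at this place is not enough by itself, since the 2-hydroxyethyl group leaves the reading at a limit, not a number. The step between compound 1 and compound 3 cannot be read, and the two compounds cannot be ordered: the limit of > 100000 nM in this assay, at which 2 of the 3 values shown sit.

The compounds shown leave open which part of the departed arm goes with the measurable number: the fluorine, the aromatic ring, the sulfonyl or the amino hydrogen. Going by these compounds, how a phenylsulfonylamino group without fluorine, a benzamide or a simple amine would read at this place also remains open.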